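Halogen swap on the anilide ring: fluoro to chloro

The compounds below may be only part of what the source reports. "The series", "measured", "known", "first", "only" and "open" are said of these compounds alone.

Compound 1 `O=C1NCCN1c1ccc(S(=O)(=O)Nc2ccc(F)cc2)cc1` in a functional assay on MCF7 cells (Homo sapiens) for antiproliferative activity, read by sulforhodamine B assay, with a stated time of 48 h (a lower number here means a stronger inhibitor, a higher number a weaker inhibitor), gives 690 nM. Of the two compounds with a number, compound 1 sits highest; its nearest neighbour is compound 2 `O=C1NCCN1c1ccc(S(=O)(=O)Nc2ccccc2)cc1`, which in this assay gives 470 nM, the gap being a 1.5-fold lower number from compound 1 to compound 2 (0.17 log units; within the scatter). Compound 3 `CC(C)(C)c1ccc(NS(=O)(=O)c2ccc(N3CCNC3=O)cc2)cc1` in this assay reaches only a limit, > 1000 nM, (the limit of > 1000 nM in this assay, at which 1 of the 3 values shown sits). From compound 1 the step to it reads an at least 1.4-fold higher number from compound 1 to compound 3 (0.16 log units; that floor lies within the scatter), and from compound 2 it reads an at least 2.1-fold higher number from compound 2 to compound 3 (0.32 log units; beyond the scatter).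

The unmeasured compound 4 `O=C1NCCN1c1ccc(S(=O)(=O)Nc2ccc(Cl)cc2)cc1` differs from compound 1 in one place: chloro in place of fluoro on an aromatic carbon. The three measured steps all concern the same aromatic carbon. Removing the fluoro altogether stays within the scatter, while putting tert-butyl there pushes the number to the limit, modestly from compound 2 and with a floor inside the scatter from compound 1. A single-atom exchange at that carbon thus gives no signal beyond the scatter in either direction, and only the bulkiest substitution did. For compound 4 the expected step is therefore a 1.2-fold higher number from compound 1 to compound 4 (0.06 log units; within the scatter), small and not clearly beyond the scatter. The estimate for compound 4 in this assay is 800 nM, within 400 nM to 1600 nM.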

Compound 4, half-maximal inhibitory concentration: 170 nM
For compound 4 the middle estimate is 4.7-fold (0.67 log units) above the measured one; the measured number lies below the stated range.
By their numbers in this assay, from the lowest: compound 4; then compounds 2 and 1 (each within the scatter of the next). At a limit, above all of these: compound 3.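

In this assay, within the data shown here, the exchange of one halogen for another on this aromatic carbon, para to a large group, gives a step beyond the scatter, a 4.1-fold lower number from compound 1 to compound 4 (0.61 log units; beyond the scatter), so a single-atom change here does register, which no earlier step showed. Chloro also stands apart from the unsubstituted ring, a 2.8-fold lower number from compound 2 to compound 4 (0.44 log units; beyond the scatter), whereas compounds 1 and 2 lie within the scatter of each other, so the two halogens do not act alike at this carbon and fluoro cannot be told from hydrogen. Compound 3 is held at a limit and not at a number, so the step from tert-butyl reads only as a floor, an at least 5.8-fold lower number from compound 3 to compound 4 (0.76 log units; beyond the scatter), which still separates the two groups at this carbon: the limit of > 1000 nM in this assay, at which 1 of the 4 values shown sits.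

With only hydrogen, fluoro, chloro and tert-butyl shown at this carbon, it remains open whether bromo, methyl, methoxy or an amine would fall with chloro or with the others. Going by these compounds, it also remains open whether the gain from chloro carries over to any other carbon of that ring.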